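From nitrile to chloro in a weak growth inhibitor

A few compounds are considered here, and "the series" means these few. Any claim that something is new, unique, unknown or untested is made for them only; others in the source may bear on it.

Measured in a functional assay on MCF7 cells (Homo sapiens); a lower number here means a stronger inhibitor of growth, a higher number a weaker inhibitor of growth:
compound 1 `N#Cc1ccc(/C=C/S(=O)(=O)Cc2ccc(Nc3ncnc4ccccc34)cc2)cc1`: > 100000 nM
compound 2 `CC(C)(C)c1cc(/C=C/S(=O)(=O)Cc2ccc(Nc3ncnc4ccccc34)cc2)cc(C(C)(C)C)c1O`: 13000 nM

In this assay compound 1 gives > 100000 nM, which is a limit and not a number. Compound 3 `O=S(=O)(/C=C/c1ccc(Cl)cc1)Cc1ccc(Nc2ncnc3ccccc23)cc1` has chloro in place of cyano on an aromatic carbon, para to a large group: chloro in place of cyano on an aromatic carbon. No measured step sizes this change. Within the data shown here, compound 2, at 13000 nM, shows only that a number can be reached with the same core. A modest gain in growth inhibition is therefore expected, and the estimated change is an at least 3.3-fold lower number from compound 1 to compound 3 (0.52 log units; beyond the scatter). For compound 3 the expected value is 30000 nM, with an estimated range of 8000 nM to 100000 nM.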

Compound 3, concentration for 50% growth inhibition: 52000 nM
Estimate against measurement, compound 3: 1.7-fold (0.24 log units) below, and the stated range covers the measured number.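

In this assay, chloro on this aromatic carbon, para to a large group, gives a number where cyano gave only a limit, and the change reads as an at least 1.9-fold lower number from compound 1 to compound 3 (0.28 log units; that floor lies within the scatter). As far as these compounds go, the true size of this step stays unknown, because compound 1 stands at a limit of the assay: the limit of > 100000 nM in this assay, at which 1 of the 3 values shown sits.

The compounds shown leave open how an amine, a carboxylic acid or a methoxy group at this position would compare with chloro. They also leave open whether bromo or fluoro would give a number close to that of compound 3.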